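Replacing thiophen-3-yl with ethynyl in compound 3

The source may hold more compounds than are shown below. What is called first, only, known or untested is meant among the compounds shown, and "the series" means these compounds.

In a functional assay on HepG2 cells (Homo sapiens) for antiproliferative activity, read by XTT assay, with a stated time of 72 h (a lower number here means a stronger inhibitor, a higher number a weaker inhibitor), compound 3 (`CN(C)c1ncnc2c1c(-c1ccsc1)cn2[C@@H]1O[C@H](CO)[C@@H](O)[C@H]1O`) records > 20000 nM as its result, which is a limit and not a number. Compound 4 (`C#Cc1cn([C@@H]2O[C@H](CO)[C@@H](O)[C@H]2O)c2ncnc(N(C)C)c12`) carries ethynyl in place of thiophen-3-yl on an aromatic carbon and is otherwise the same as compound 3. Going by the values given here, no measured step makes this exchange, so the nearest evidence comes from two other compounds that carry ethynyl. In this assay compound 1 (`C#Cc1cn([C@@H]2O[C@H](CO)[C@@H](O)[C@H]2O)c2ncnc(OC)c12`) gives 12700 nM as a measured number. Compound 2 (`C#Cc1cn([C@@H]2O[C@H](CO)[C@@H](O)[C@H]2O)c2ncnc(NC)c12`) records > 15000 nM as its result, which is also a limit. Among the compounds with values here, the only measured step is an at least 1.1-fold higher number from compound 1 to compound 2 (0.07 log units; that floor lies within the scatter) and it concerns methoxy and methylamino, not the group exchanged here. Within the data shown here, with compound 1 at 12700 nM as the only number for an ethynyl compound, no step beyond the scatter is expected in this assay here. The expected change is an at least 1.2-fold lower number from compound 3 to compound 4 (0.09 log units; that floor lies within the scatter) as estimated from these few data. For compound 4 the estimated value is 16000 nM with an expected range from 7000 nM to 35000 nM in that assay.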

Compound 4, half-maximal inhibitory concentration: 1320 nM
Compound 4: the middle estimate sits 12-fold (1.08 log units) above what was measured, and the stated range ends above it.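

In this assay, the exchange of thiophen-3-yl for ethynyl on this aromatic carbon gives an at least 15-fold lower number from compound 3 to compound 4 (1.18 log units; beyond the scatter), and that step is a floor, as compound 3 holds only a limit: the limit of > 20000 nM in this assay, at which 1 of the 4 values shown sits.

The earlier compounds shown here also left unclear whether the amine carried by an ethynyl compound mattered, and here the step with methyl in place of hydrogen on the nitrogen gives an at least 11-fold lower number from compound 2 to compound 4 (1.05 log units; beyond the scatter), while dimethylamino in place of methoxy gives a 9.6-fold lower number from compound 1 to compound 4 (0.98 log units; beyond the scatter). The first of these steps is also a floor, as compound 2 holds only a limit: the limit of > 15000 nM in this assay, at which 1 of the 4 values shown sits.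

Thiophen-3-yl appears here only with dimethylamino, so it stays open whether ethynyl would bring the same gain with methoxy or methylamino on the core. Going by these compounds, how a nitrile or a propynyl group would fare on this aromatic carbon also remains open.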